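Aromatic bromo substitution on compound 1: working notes

The source may hold more compounds than are shown below. What is called first, only, known or untested is meant among the compounds shown, and "the series" means these compounds.

Two compounds of the series have numbers in an assay on membranes from brain for displacement of a labelled ligand from Sigma non-opioid intracellular receptor 1 (Cavia porcellus), read by scintillation counting, with a stated time of 120 min; a higher number here means a weaker inhibitor, a lower number a stronger inhibitor. Compound 1 `c1ccc(CCCNC2CCc3ccsc3CC2)cc1` gives 187 nM and stands highest of the two. Among the measured compounds shown here, compound 2 `c1ccc(CCCCNC2CCc3ccsc3CC2)cc1` gives 62 nM; the step of a 3.0-fold lower number from compound 1 to compound 2 (0.48 log units; beyond the scatter) is modest and is the only measured step. Compound 3 `Brc1cc2c(s1)CCC(NCCCc1ccccc1)CC2` has not been measured. It differs from compound 1 by bromo in place of hydrogen on an aromatic carbon, on an aromatic carbon of a five-membered aromatic ring with 1 sulfur, part of a fused system of two rings. For the measured compounds named here, no measured step bears on this change: the step from compound 1 to compound 2 concerns the chain, not the ring, and no other pair differs at an aromatic carbon. The series therefore gives no direction for this change, and no step beyond the scatter in this assay is expected. For compound 3 the expected value is 150 nM, range 50 nM to 450 nM, which as an estimated step means a 1.2-fold lower number from compound 1 to compound 3 (0.10 log units; within the scatter).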

Compound 3, inhibition constant: 41 nM
For compound 3 the middle estimate is 3.7-fold (0.56 log units) above the measured one; measured number outside the range, below it.
By their numbers in this assay, from the lowest: compounds 3 and 2 (each within the scatter of the next); then compound 1.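

In this assay bromo in place of hydrogen on an aromatic carbon, next to the ring sulfur, brings a 4.6-fold lower number from compound 1 to compound 3 (0.66 log units; beyond the scatter) and so counts as a real change. Among the compounds shown here, this is the first measured step on the ring rather than the chain, so the number responds at this ring position as well, and a bromine here comes with a lower number, not a higher one. No measurement shown accounts for the size or the direction of this step.

One substituent at one position cannot say whether the step belongs to bromo itself or would also appear with chloro, methyl or a nitrile at the same carbon. Also open, from the compounds shown here alone, is whether bromo at this position and the longer chain of compound 2 would add up in one compound.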